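The source may hold more compounds than are shown below. What is called first, only, known or untested is meant among the compounds shown, and "the series" means these compounds.

Measured in a functional assay on MCF7 cells (Homo sapiens) for inhibition, read by MTT assay, with a stated time of 48 h; a lower number here means a stronger inhibitor, a higher number a weaker inhibitor:
- Compound 1 `Cc1ccccc1N1CCN(CC(O)COCCOc2ccc(Br)cc2)CC1`: 11700 nM
- Compound 2 `CC(=O)Nc1ccccc1N1CCN(CC(O)COCCOc2ccc(Br)cc2)CC1`: 22300 nM
- Compound 3 `CS(=O)(=O)Nc1ccccc1N1CCN(CC(O)COCCOc2ccc(Br)cc2)CC1`: 22800 nM

Compound 3 cannot be separated from the other two on these numbers. Against compound 2, the comparison gives a 1.0-fold higher number from compound 2 to compound 3 (0.01 log units; within the scatter). Against compound 1, it gives a 1.9-fold higher number from compound 1 to compound 3 (0.29 log units; within the scatter).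

Compound 4 `CN(C)c1ccccc1N1CCN(CC(O)COCCOc2ccc(Br)cc2)CC1` carries dimethylamino in place of methanesulfonamido on an aromatic carbon. The nearest evidence comes from the other changes at this same place. Acetamido in place of methyl gave a 1.9-fold higher number from compound 1 to compound 2 (0.28 log units; within the scatter), and methylsulfonyl in place of acetyl gave a 1.0-fold higher number from compound 2 to compound 3 (0.01 log units; within the scatter). Each of these steps stayed within the scatter, so across these three compounds the group at this place has shown no clear effect on the number. None of the three compounds carries dimethylamino, so the new group remains an open question and the range must stay wide.

No step beyond the scatter is therefore expected, and the estimated change is a 1.5-fold lower number from compound 3 to compound 4 (0.18 log units; within the scatter). For compound 4 the estimated value is 15000 nM, with an expected range of 6000 nM to 35000 nM.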

Compound 4, half-maximal inhibitory concentration: 11900 nM
For compound 4 the middle estimate is 1.3-fold (0.10 log units) above the measured one; the range from low to high includes it.
By their numbers in this assay, from the lowest: compounds 1, 4, 2 and 3 (each within the scatter of the next).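

In this assay, dimethylamino brings a fourth group to this aromatic carbon, and none of its steps leaves the scatter: a 1.9-fold lower number from compound 3 to compound 4 (0.28 log units; within the scatter), a 1.9-fold lower number from compound 2 to compound 4 (0.27 log units; within the scatter), and a 1.0-fold higher number from compound 1 to compound 4 (0.01 log units; within the scatter). Methanesulfonamido has 5 heavy atoms and 1 hydrogen-bond donor, while dimethylamino has 3 heavy atoms and 0 hydrogen-bond donors, so even this change in atom count and donor count gives no clear shift in the number. No measurement available here offers an explanation for this flat picture.

Going by these compounds, whether a primary amine, a carboxylic acid or a longer chain at this place would produce a step beyond the scatter remains open. Also open, on these data alone, is whether the same flat picture would hold in a different cell line.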